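Chloro Substitution on the Anilide Ring of Dithiol Amides

The compounds below may be only part of what the source reports. "The series", "measured", "known", "first", "only" and "open" are said of these compounds alone.

Measured so far:
compound 1, `O=C(CCCCC(S)CCS)Nc1ccccc1`, 1.32%
compound 2, `O=C(CCCCC(S)CCS)Nc1cccc(Cl)c1`, 1.14%
compound 3, `O=C(CCCCC(CCSC(=O)c1ccccc1)SC(=O)c1ccccc1)Nc1ccccc1`, "not active" (no number reported), with no number

In a functional assay on Bel-7402 cells (Homo sapiens) for inhibition, read by MTT assay, with a stated time of 24 h, tested at 1 ug/mL (a higher number here means more inhibition of growth at the concentration tested, a lower number less inhibition of growth), compound 1 gives 1.32%. Compound 2 carries chloro in place of hydrogen on an aromatic carbon, and the step of a number 0.2 percentage points lower from compound 1 to compound 2 (within the scatter). Compound 3 is the dibenzoylated analogue; the difference between its core and that of compound 1 is not broken down here, and in this assay compound 3 is reported as "not active" (no number reported) without a number.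

Compound 4, `O=C(CCCCC(CCSC(=O)c1ccccc1)SC(=O)c1ccccc1)Nc1ccccc1Cl`, is not yet measured. It differs from compound 3 by chloro in place of hydrogen on an aromatic carbon. Among the compounds with values here, this is the same kind of change as the one from compound 1 to compound 2, but not the same: there the chloro sits meta to a large group, here ortho to a large group. That earlier step lay within the scatter, and compound 3, the parent of compound 4, showed no activity at all, so a small step is expected again.

Compound 4 is therefore estimated to give 2% in this assay, with a range from 0% to 12% expected.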

Compound 4, percent growth inhibition at one concentration: 7.37%
Estimate against measurement, compound 4: 5.4 percentage points below, within the range that was stated.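

Within the data shown here, no step from compound 3 to compound 4 can be read in this assay: compound 3 is reported as "not active" (no number reported) and compound 4 gives 7.37%, so the pair has no size of change. The compounds shown leave open what chloro in place of hydrogen does on this dibenzoylated core. No supporting evidence bears on this result.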